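Trading an arylamino group for phenyl on the carbonyl

The compounds below may be only part of what the source reports. "The series", "measured", "known", "first", "only" and "open" are said of these compounds alone.

Compound 1, `O=C(Nc1cccc(-n2cc(-c3ccncc3)c(-c3ccc(Cl)c(O)c3)n2)c1)Nc1cccc(C(F)(F)F)c1`, in a functional assay on NCI-H226 cells (Homo sapiens) for inhibition, read by sulforhodamine B assay, with a stated time of 48 h; a higher number here means a weaker inhibitor of growth, a lower number a stronger inhibitor of growth: 7350 nM
Compound 2, `COc1cc(-c2nn(-c3cccc(NC(=O)Nc4cc(C(F)(F)F)cc(C(F)(F)F)c4)c3)cc2-c2ccncc2)ccc1Cl`, in this assay: 1360 nM
Compound 3, `COc1cc(-c2nn(-c3cccc(NC(=O)Nc4cccc(C(F)(F)F)c4)c3)cc2-c2ccncc2)ccc1Cl`, in this assay: 1380 nM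

Compound 3 gives the second highest of the three numbers. Its nearest neighbour is compound 2, whose value sits within the scatter of it, as the step of a 1.0-fold higher number from compound 2 to compound 3 (0.01 log units; within the scatter) shows. The largest gap separates it from compound 1: the step of a 5.3-fold lower number from compound 1 to compound 3 (0.73 log units; beyond the scatter) comes from a methyl in place of hydrogen on an oxygen on an aromatic ring.

Compound 4, `COc1cc(-c2nn(-c3cccc(NC(=O)c4ccccc4)c3)cc2-c2ccncc2)ccc1Cl`, has not been measured. It differs from compound 3 in one place: phenyl in place of (3-(trifluoromethyl)phenyl)amino on a carbonyl carbon. Among the compounds with values here, no measured step touches the amino part of that group; the only step near it, a 1.0-fold higher number from compound 2 to compound 3 (0.01 log units; within the scatter), concerns a trifluoromethyl on the aromatic ring and stayed within the scatter. The whole group leaves here, donor included, so the step of a 3.3-fold higher number from compound 3 to compound 4 (0.51 log units; beyond the scatter) is expected to be a modest rise in the number, with wide uncertainty. Compound 4 is therefore estimated at 4500 nM, in a range from 1200 nM to 17000 nM.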

Compound 4, concentration for 50% growth inhibition: 2350 nM
The estimate for compound 4 lay 1.9-fold (0.28 log units) above the measured number; measured number inside the range.
By their numbers in this assay, from the lowest: compounds 2, 3 and 4 (each within the scatter of the next); then compound 1.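

At the carbonyl carbon, the whole (3-(trifluoromethyl)phenyl)amino group, its hydrogen-bond donor included, gave way to phenyl with a 1.7-fold higher number from compound 3 to compound 4 (0.23 log units; within the scatter) in this assay, so the two compounds cannot be told apart in this assay. The earlier compounds shown here had varied only a trifluoromethyl on an aromatic ring and a methyl on an oxygen, whereas this step shows that the amide-type linkage itself can change without a step beyond the scatter. No evidence at hand accounts for this result.

Going by these compounds, the amino nitrogen and the trifluoromethyl leave together here, so what each contributes on its own stays open. Also open, on these data alone, is whether a carbonyl bearing a morpholine ring or a short alkyl chain in place of phenyl would give a number close to that of compound 4.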